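A few compounds are considered here, and "the series" means these few. Any claim that something is new, unique, unknown or untested is made for them only; others in the source may bear on it.

In an assay on isolated protein for inhibition of leukotriene B4 receptor 1 (Homo sapiens), tested at 10 uM (on this read-out higher numbers stand for more inhibition at the one concentration tested (going by the name of the read-out) and lower numbers for less inhibition), compound 2 `CCc1cc(C(C)=O)c(O)cc1OCCCCCCCC(C)(C)C#N` gives 66%, the second highest of the three numbers measured. Compound 3 `CCc1cc(C(C)=O)c(O)cc1OCCCCCC(C)(C)c1nnnn1C` gives 99%, and compound 1 `CC(=O)c1cc(CC(C)O)c(OCCCCC#N)cc1O` gives 10%. Compound 4 `CCc1cc(C(C)=O)c(O)cc1OCCCCc1nnn[nH]1` has not been measured; it differs from compound 2 in one place, (1H-tetrazol-5-yl in place of 4-cyano-4-methylpentyl on a saturated chain carbon, four bonds along the chain from an oxygen on an aromatic ring). Among the measured compounds shown here, one measured step bears on this: a number 33 percentage points higher from compound 2 to compound 3 (beyond the scatter), where a nitrile-bearing group gave way to a 1-methyl-1H-tetrazol-5-yl-bearing one. Compound 4 makes the same kind of exchange, a nitrile leaving and a 1H-tetrazol-5-yl entering, so an upward step is expected, a number 19 percentage points higher from compound 2 to compound 4 (beyond the scatter), though the entering group here lacks the two methyls. In this assay compound 4 is expected to give about 85%, within a range from 60% to 99%.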

Compound 4, a percentage reported as inhibition, at one concentration (the size of the read-out at that concentration, not a potency): 49%
Estimate against measurement, compound 4: 36 percentage points above, and the stated range ends above it.
By their numbers in this assay, from the lowest: compound 1; then compound 4; then compound 2; then compound 3.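

In this assay, a tetrazole entering this position does not by itself raise the number: the 1H-tetrazol-5-yl on the shorter chain brings a fall (a number 17 percentage points lower from compound 2 to compound 4 (beyond the scatter)), against the rise seen with the 1-methyl-1-(1-methyl-1H-tetrazol-5-yl)ethyl group (a number 33 percentage points higher from compound 2 to compound 3 (beyond the scatter)). The direction of this exchange therefore depends on what comes with the ring, not on the ring alone. No measurement here explains the fall. Still open, as far as these compounds go, is how a longer chain carrying the 1H-tetrazol-5-yl would read, and whether a carboxylic acid in its place would behave alike.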